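The source may hold more compounds than are shown below. What is called first, only, known or untested is meant among the compounds shown, and "the series" means these compounds.

Measured so far:

compound 1, `O[C@@H](COc1ccc(C(F)(F)F)cc1)CN1CCN(c2ccccc2F)CC1`, gives 50.2% in an assay on HEK293 cells for inhibition of Voltage-dependent T-type calcium channel subunit alpha-1G (Homo sapiens), read by patch clamp, tested at 10 uM; a higher number here means more inhibition at the concentration tested (going by the name of the read-out), a lower number less inhibition.
compound 2, `COc1ccccc1N1CCN(C[C@H](O)COc2ccc(Cl)cc2)CC1`, gives 48.8% in this assay.
compound 3, `O[C@@H](COc1ccc(F)cc1)CN1CCN(c2ccc(F)cc2)CC1`, gives 47.5% in this assay.

Compound 2 stands second highest of the three numbers, but its gap to compound 3 and its gap to compound 1 both lie within the scatter, so the three compounds cannot be told apart by these values. The step under review goes from compound 2 to compound 4, `O[C@H](COc1ccc(Cl)cc1)CN1CCN(c2ccccc2F)CC1`, not yet measured in this assay. The change is fluoro in place of methoxy on an aromatic carbon, sitting ortho to a large group on the six-membered aromatic ring of carbon only. Among the measured compounds shown here, no measured pair shows this exchange. Since compound 1, which carries the fluoro, gives 50.2%, the step is expected to be none beyond the scatter, a number 0.7 percentage points higher from compound 2 to compound 4 (within the scatter). Compound 4 is estimated at 49.5%, between 39% and 60%.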

Compound 4, a percentage reported as inhibition, at one concentration (the size of the read-out at that concentration, not a potency): 35.9%
For compound 4 the middle estimate is 13.6 percentage points above the measured one, outside the stated range (below it).
By their numbers in this assay, from the lowest: compound 4; then compounds 3, 2 and 1 (each within the scatter of the next).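

Swapping methoxy for fluoro at this place is the first change in these compounds to move the number in this assay beyond the scatter, with a number 12.9 percentage points lower from compound 2 to compound 4 (beyond the scatter) as the step. The three earlier values could not be told apart, so they gave no sign that this position responds to what it carries, whereas this pair shows that it does. No measurement shown here explains the drop.

On these data alone, what remains open is whether an amine or a nitrile in the same place would give a number closer to that of compound 2 or of compound 4. As far as these compounds go, it is also open whether the same exchange gives a step of similar size when the rest of the molecule differs.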